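Compounds Sharing a Core, All Inactive So Far; Compound 4 Next

The source may report more compounds than this note shows. Statements on the series, on what has been measured and on what is new or still open speak of the compounds shown alone.

Compound 1 `COc1ccc(-c2cn(C[C@H]3c4c(ccc(O)c4C)[C@@H]4CC[C@@]5(C)C[C@]43CC5=O)nn2)cc1`: > 20000 nM in a functional assay on SMMC-7721 cells (Homo sapiens) for cytotoxicity, read by MTT assay, with a stated time of 4 days (a lower number here means a stronger inhibitor, a higher number a weaker inhibitor), a limit of the assay.
Compound 2 `Cc1ccc(S(=O)(=O)Oc2ccc3c(c2C)[C@H](Cn2cc(-c4ccc(C(F)(F)F)cc4)nn2)[C@@]24CC(=O)[C@@](C)(CC[C@@H]32)C4)cc1`: > 20000 nM, a limit of the assay.
Compound 3 `Cc1ccc(S(=O)(=O)Oc2ccc3c(c2C)[C@H](Cn2cc(-c4ccc(F)cc4)nn2)[C@@]24CC(=O)[C@@](C)(CC[C@@H]32)C4)cc1`: > 20000 nM, a limit of the assay.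

Among the measured compounds shown here, none of the three compounds measured so far has given a number in this assay; each sits at the limit of > 20000 nM in this assay, at which 3 of the 3 values shown sit. For the measured compounds named here, the one step that can be drawn between measured compounds, a step that the two limits leave unreadable from compound 2 to compound 3, therefore cannot be sized: both ends are limits, so the change from trifluoromethyl to fluoro may have had any effect or none. Compound 3 thus stands at the limit, with no number of its own to build on.

Compound 4 `COc1ccc(-c2cn(C[C@H]3c4c(ccc(OS(=O)(=O)c5ccc(C)cc5)c4C)[C@@H]4CC[C@@]5(C)C[C@]43CC5=O)nn2)cc1` differs from compound 3 by methoxy in place of fluoro on an aromatic carbon, which cut one bond further out reads as 4-fluorophenyl to 4-methoxyphenyl. Going by the values given here, no measured step bears directly on this change. Among the compounds with values here, the only guidance is that compound 1, which also carries the 4-methoxyphenyl group, gives a limit, and that every value shown is a limit.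

Compound 4 is therefore expected to remain at the limit as well, with an estimated step that the limit leaves unreadable from compound 3 to compound 4 that is not readable as a real change. The estimate for compound 4 is 40000 nM, between 10000 nM and 160000 nM.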

Compound 4, half-maximal inhibitory concentration: > 20000 nM
Compound 4 was reported as a limit; the forecaster's own chance of this, stated with the estimate: 85%; the middle value does not contradict the limit.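

Compound 4 also sits at a limit of the assay, so its steps from compound 1, compound 2 and compound 3 cannot be read, with limits at both ends of each: the limit of > 20000 nM in this assay, at which 4 of the 4 values shown sit.

As far as these compounds go, whether methoxy, fluoro or trifluoromethyl, or (4-methylphenyl)sulfonyl in place of hydrogen, makes any difference in this assay stays open, as does what on the shared core would give a measurable number.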